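Cytotoxicity of Benzimidazole Amides and Carbamates on Vero Cells

A few compounds are considered here, and "the series" means these few. Any claim that something is new, unique, unknown or untested is made for them only; others in the source may bear on it.

Compound 1 `O=C(CCc1ccccc1)Nc1cc2nc(C3CCCCC3)[nH]c2cc1N1CCCC1` gives > 100 ug/mL in an ADME assay on Vero cells (Chlorocebus sabaeus) for cytotoxicity, read by resazurin assay, with a stated time of 3 days; a lower number here means a stronger inhibitor, a higher number a weaker inhibitor; this is a limit of the assay, not a measured number.
Compound 2 `CCCN(CCC)c1cc2[nH]c(C3CCCCC3)nc2cc1NC(=O)OCc1ccccc1` gives > 100 ug/mL in this assay; this too is a limit of the assay rather than a number.

Going by the values given here, compound 1 therefore stands at the top edge of what this assay can report, and both values known so far sit at the same place, as the limit of > 100 ug/mL in this assay, at which 2 of the 2 values shown sit, shows. Among the compounds with values here, nothing measured yet separates the two compounds, so no step between them can be sized.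

Compound 3 `COCCOC(=O)Nc1cc2nc(C3CCCCC3)[nH]c2cc1N1CCCC1` differs from compound 1 in one place: 2-methoxyethoxy in place of phenethyl on a carbonyl carbon. The rest of the shared core, including the cyclohexyl group and the pyrrolidine ring, is unchanged.

Since both known values rest at the limit of > 100 ug/mL in this assay, at which 2 of the 2 values shown sit, the expected step in this assay is none beyond the usual scatter, and compound 3 is expected to remain at or beyond the limit as well. On that basis compound 3 is estimated at 150 ug/mL, within a range of 60 ug/mL to 400 ug/mL. The expected change this implies, a step that the limit leaves unreadable from compound 1 to compound 3, is small.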

Compound 3, half-maximal inhibitory concentration: > 100 ug/mL
Compound 3: only a limit was reported; the forecaster's own chance of this, stated with the estimate: 85%; the middle value is on the limit's open side.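

No step from compound 1 to compound 3 can be read in this assay, because each result is a limit and not a number: the limit of > 100 ug/mL in this assay, at which 3 of the 3 values shown sit.

The compounds shown leave open how far past that limit each one lies, and whether 2-methoxyethoxy in place of phenethyl on a carbonyl carbon alters cytotoxicity at all.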